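This account rests on a few compounds, and the source may have more. Where it says the series, first, only, none or still open, it means among the compounds named here.

Measured so far:
- Compound 1 `CCn1cc(C(CC)(CC)c2ccc(C#CC(O)(CC)CC)c(C)c2)cc1C(=O)NCC(=O)OC`: 26500 nM
- Compound 2 `CCn1cc(C(CC)(CC)c2ccc(C#CC(O)(CC)CC)c(C)c2)cc1C(=O)NCCN(C)C`: 13400 nM

Among the compounds with values here, in a functional assay on MCF7 cells (Homo sapiens) for antiproliferative activity, read by MTT assay, with a stated time of 72 h (on this read-out higher numbers stand for weaker inhibition and lower numbers for stronger inhibition), compound 2 gives 13400 nM, and only one other measured compound stands beside it. Within the data shown here, the single measured step between the two is a 2.0-fold lower number from compound 1 to compound 2 (0.30 log units; within the scatter), so compound 2 cannot be told apart from its only neighbour.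

Compound 3 `CCn1cc(C(CC)(CC)c2ccc(C#CC(O)(CC)CC)c(C)c2)cc1C(=O)NCCCN(C)C` has not yet been measured. Its structure departs from compound 2 as follows: (dimethylamino)methyl in place of dimethylamino on a saturated chain carbon, two bonds along the chain from an amide-type nitrogen. Among the measured compounds shown here, that single measured step swapped a different pair of groups, so it is only a loose guide, and no measurement yet tests this change. For the measured compounds named here, with compound 2 at 13400 nM and a step of a 2.0-fold lower number from compound 1 to compound 2 (0.30 log units; within the scatter) as the only evidence, no shift beyond the scatter and no particular direction is expected in this assay. The expected step is a 1.0-fold lower number from compound 2 to compound 3 (0.01 log units; within the scatter). For compound 3 the estimated value is 13000 nM, with an expected range of 5500 nM to 30000 nM.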

Compound 3, half-maximal inhibitory concentration: 20200 nM
Compound 3: the middle estimate sits 1.6-fold (0.19 log units) below what was measured; the range from low to high includes it.
By their numbers in this assay, from the lowest: compounds 2, 3 and 1 (each within the scatter of the next).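

In this assay one extra chain carbon, turning 2-(dimethylamino)ethyl into 3-(dimethylamino)propyl, gives a 1.5-fold higher number from compound 2 to compound 3 (0.18 log units; within the scatter) and so cannot be told apart from no change at all. Setting 2-(dimethylamino)ethyl in place of methoxycarbonyl on the saturated chain carbon bound to the amide-type nitrogen gives a 1.3-fold lower number from compound 1 to compound 3 (0.12 log units; within the scatter) and likewise separates nothing, so all three side chains read alike here, whether they end in an amine or in methoxycarbonyl. No other measurement on these compounds bears on this result.

Still open, on these data alone, is whether any group at this position can move the number beyond the scatter, for example a carboxylic acid, a ring amine such as morpholine, or a longer chain. Whether changing the shared core matters more than this side chain also remains unanswered.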